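A few compounds are considered here, and "the series" means these few. Any claim that something is new, unique, unknown or untested is made for them only; others in the source may bear on it.

Compound 1, `COc1ccc(Oc2ccc3c(NCCCNCc4cc(F)ccc4OC)ccnc3c2)cc1`, gives 317 10^-6 cm/s in an ADME assay for permeability, using PAMPA, with a stated time of 30 min, at pH 7.4; on this read-out higher numbers stand for higher permeability and lower numbers for lower permeability.
Compound 2, `COc1ccc(Oc2ccc3c(NCCCNCc4cccc(OC)c4O)ccnc3c2)cc1`, gives 317 10^-6 cm/s in this assay.
Compound 3, `c1coc(CNCCCNc2ccnc3cc(CC4CCCCC4)ccc23)c1`, gives 23 10^-6 cm/s in this assay.

Compound 1 thus stands level with compound 2 at the top of these three numbers, and compound 3 stands well below it, beyond the scatter. For the measured compounds named here, the one measured step, no change at the digits printed from compound 1 to compound 2 (within the scatter), concerns the amine end of the chain and shows no change beyond the scatter. Compound 3 differs from compound 1 in more than one place, so its lower number cannot be tied to any single change.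

Compound 4, `COc1ccc(F)cc1CNCCCNc1ccnc2cc(Cc3ccc(F)cc3)ccc12`, is not yet measured. It differs from compound 1 by 4-fluorobenzyl in place of 4-methoxyphenoxy on an aromatic carbon. Going by the values given here, no measured step touches this position, so the only guide is that a change at the other end of the molecule left this assay unmoved, and that compound 3, which carries a different group at this same position among other differences, sits lower. A modest drop is therefore expected, though it may stay within the scatter: the expected step is a 1.6-fold lower number from compound 1 to compound 4 (0.20 log units; within the scatter). Compound 4 is estimated at 200 10^-6 cm/s, with a likely range from 60 10^-6 cm/s to 400 10^-6 cm/s.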

Compound 4, apparent permeability: 23 10^-6 cm/s
Estimate against measurement, compound 4: 8.7-fold (0.94 log units) above, and the stated range ends above it.
By their numbers in this assay, from the lowest: compounds 3 and 4 (each within the scatter of the next); then compounds 1 and 2 (each within the scatter of the next).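

For the compounds shown here, the position on the aromatic carbon carrying this group matters in this assay: putting 4-fluorobenzyl in place of 4-methoxyphenoxy gives a 14-fold lower number from compound 1 to compound 4 (1.14 log units; beyond the scatter) and so moves the number far more than the only earlier step, no change at the digits printed from compound 1 to compound 2 (within the scatter), made at the amine end of the chain. The swap looks modest on paper, since both groups hold one six-membered aromatic ring of carbon only and no net charge, while 4-methoxyphenoxy has 2 hydrogen-bond acceptors and 4-fluorobenzyl has 0. Nothing in the data shown gives a cause for this large step.

The swap alters both the atom linking the aromatic ring to the core and the group on that ring, so the compounds shown leave open which of these two alterations carries the step. A 4-fluorophenoxy or a 4-methoxybenzyl group on the same carbon would separate the two, and a morpholine there would test whether this position tolerates something without an aromatic ring.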